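A Dodecyl Tetrazole Pair and One Shared Amide Swap

The compounds below may be only part of what the source reports. "The series", "measured", "known", "first", "only" and "open" are said of these compounds alone.

Compound 1 `CCCCCCCCCCCCn1nnc(C(NC(=O)c2c(C)cccc2C)c2ccccc2)n1` and compound 3 `CCCCCCCCCCCCn1nnnc1C(NC(=O)c1c(C)cccc1C)c1ccccc1` are built from the same atoms joined differently; how their two cores differ is not broken down here. In an assay on microsomes from liver for inhibition of sterol O-acyltransferase 1 (Rattus norvegicus) (on this read-out lower numbers stand for stronger inhibition and higher numbers for weaker inhibition), compound 1 gives 310 nM and compound 3 gives 180 nM. Compound 2 `CCCCCCCCCCCCn1nnc(C(NC(=O)c2ccc(F)cc2F)c2ccccc2)n1` arises from compound 1 through 2,4-difluorophenyl in place of 2,6-dimethylphenyl on a carbonyl carbon and in this assay compound 2 gives 490 nM, a step of a 1.6-fold higher number from compound 1 to compound 2 (0.20 log units; within the scatter); compound 3 gives a lower number than compound 2 by a margin beyond the scatter. Compound 4 `CCCCCCCCCCCCn1nnnc1C(NC(=O)c1ccc(F)cc1F)c1ccccc1` arises from compound 3 by the same change, (2,4-difluorophenyl in place of 2,6-dimethylphenyl on a carbonyl carbon), at a place described in the same words. Because the earlier step was a 1.6-fold higher number from compound 1 to compound 2 (0.20 log units; within the scatter), the step from compound 3 to compound 4 is expected to be a 1.6-fold higher number from compound 3 to compound 4 (0.21 log units; within the scatter). Compound 4 is therefore estimated at 290 nM in this assay, with a likely range from 130 nM to 650 nM.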

Compound 4, half-maximal inhibitory concentration: 380 nM
Beside the measured number, compound 4's estimate is 1.3-fold (0.12 log units) below it; measured number inside the range.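

In this assay, putting 2,4-difluorophenyl in place of 2,6-dimethylphenyl on a carbonyl carbon gives a 2.1-fold higher number from compound 3 to compound 4 (0.32 log units; beyond the scatter). Set beside the earlier step, the change carries over between the two cores with no difference that can be told apart: the same change on two cores in this assay, a 1.6-fold higher number (0.20 log units; within the scatter) from compound 1 to compound 2 and a 2.1-fold higher number (0.32 log units; beyond the scatter) from compound 3 to compound 4, 1.3-fold (0.13 log units) apart, within the scatter of two such steps. This is one pair of steps in one assay, so it shows agreement on these two cores only, and it does not show that the change would carry to any other core or why either step has its size.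

All four compounds share the dodecyl chain, which leaves open what an octyl chain or a chain ending in a carboxylic acid would do in its place. Also open, as far as these compounds go, is whether an amine on the phenyl ring of the amide would shift the numbers in this assay.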